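The source may hold more compounds than are shown below. What is called first, only, known or untested is meant among the compounds shown, and "the series" means these compounds.

Compound 3, `Cc1ccccc1Oc1ccc(CC2SC(=O)NC2=O)cc1`: 124 nM
Compound 1, `Cc1cc(Oc2ccc(CC3SC(=O)NC3=O)cc2)nc(C(F)(F)F)c1`: 688 nM
Compound 2, `O=C1NC(=O)C(Cc2ccc(Sc3ccccc3)cc2)S1`: 5060 nM

Three compounds share one core and differ in the group hung from it. In a functional assay for agonist activity at Free fatty acid receptor 1 (Homo sapiens), read by FLIPR, in the presence of a further agent that is not named here (a lower number here means that less compound is needed, a higher number that more compound is needed for the effect), compound 3 gives 124 nM, the lowest number of the three. Compound 1 gives 688 nM, a higher number that lies beyond the usual scatter, and compound 2 gives 5060 nM, higher still and also beyond the scatter.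

Compound 4, `Cc1cccc(Oc2ccc(CC3SC(=O)NC3=O)cc2)c1`, is the next compound, not yet measured. It keeps every atom of compound 3 and only rearranges them: 3-methylphenyl in place of 2-methylphenyl on an oxygen on an aromatic ring. For the measured compounds named here, no measured pair here shows the effect of moving a methyl from one spot on that ring to another, so the expectation rests on compound 3 alone. Such a rearrangement often changes the number only modestly, and the step from compound 3 to compound 4 is expected to be a 1.8-fold higher number from compound 3 to compound 4 (0.25 log units; within the scatter), at the edge of the scatter or a little beyond it, toward a higher number. Compound 4 is therefore estimated at 220 nM, with a range from 60 nM to 800 nM.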

Compound 4, half-maximal effective concentration: 203 nM
Estimate against measurement, compound 4: 1.1-fold (0.03 log units) above, and the stated range covers the measured number.
By their numbers in this assay, from the lowest: compounds 3 and 4 (each within the scatter of the next); then compound 1; then compound 2.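

In this assay, for the compounds shown here, 3-methylphenyl in place of 2-methylphenyl on an oxygen on an aromatic ring gives a 1.6-fold higher number from compound 3 to compound 4 (0.21 log units; within the scatter), the first comparison here of compounds that differ in one place. This assay therefore does not separate these two methylphenyl groups: at this position, moving the methyl from one spot on the ring to the other leaves the two numbers within the usual scatter of each other. Nothing measured here explains why the two groups read alike.

Open, on these data alone, is how a plain phenyl without any methyl would read on that oxygen, which would show whether the methyl matters at all. Also open, as far as these compounds go, is whether a different group on that ring, such as a methoxy group or a carboxylic acid, would stay in the same range.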